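The compounds below may be only part of what the source reports. "The series", "measured", "known", "first", "only" and "open" are said of these compounds alone.

Values in an assay for inhibition of Fatty-acid amide hydrolase 1 (Rattus norvegicus); on this read-out lower numbers stand for stronger inhibition and higher numbers for weaker inhibition:

Compound 1 `O=C(O)c1ccc(-c2cnc(CCCc3ccc(-c4ccccc4)cc3)o2)nc1`: 20000 nM
Compound 2 `COC(=O)c1ccc(-c2cnc(CCCc3ccc(-c4ccccc4)cc3)o2)nc1`: 50000 nM
Compound 3 `O=C(O)c1ccc(-c2cnc(C(=O)CCc3ccc(COc4ccccc4)cc3)o2)nc1`: 4.6 nM

Compound 1 and compound 2 share one core and differ by methyl in place of hydrogen on an oxygen next to a carbonyl group. That change gave a 2.5-fold higher number from compound 1 to compound 2 (0.40 log units; beyond the scatter), a weakening beyond the usual scatter of repeats.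

Compound 3 sits on a different core, and its number is the lowest of the three, with the gap to compound 1 and to compound 2 each beyond the scatter. The difference between the core of compound 3 and the core of compound 1 is not broken down here.

Compound 4 `COC(=O)c1ccc(-c2cnc(C(=O)CCc3ccc(COc4ccccc4)cc3)o2)nc1` is not yet measured. It differs from compound 3 by methyl in place of hydrogen on an oxygen next to a carbonyl group, the same change as from compound 1 to compound 2, at a place described in the same words. On that one precedent, the expected step in this assay is a 2.6-fold higher number from compound 3 to compound 4 (0.42 log units; beyond the scatter), a modest weakening of the same order as the earlier one, because the earlier change gave a 2.5-fold higher number from compound 1 to compound 2 (0.40 log units; beyond the scatter). The number expected for compound 4 in this assay is 12 nM, with a likely range from 4 nM to 40 nM.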

Compound 4, inhibition constant: 3.5 nM
Beside the measured number, compound 4's estimate is 3.4-fold (0.54 log units) above it, outside the stated range (below it).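

In this assay, methyl in place of hydrogen on an oxygen next to a carbonyl group gave a 1.3-fold lower number from compound 3 to compound 4 (0.12 log units; within the scatter), so carboxy and methoxycarbonyl cannot be told apart on this core. The change therefore does not carry over as one fixed step from one core to another in this series, and the earlier weakening does not transfer to the core of compound 3: the same change on two cores in this assay, a 2.5-fold higher number (0.40 log units; beyond the scatter) from compound 1 to compound 2 and a 1.3-fold lower number (0.12 log units; within the scatter) from compound 3 to compound 4, 3.3-fold (0.52 log units) apart, beyond the scatter of two such steps

For the compounds shown here, this rests on only two pairs, and the two cores differ in more than one place, so the result shows that the size of the step depends on the core but does not show which part of the core sets it.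

As far as these compounds go, it remains open whether an ethyl ester or a primary amide in place of the carboxy group would follow the step seen on the core of compound 1 or the one seen on the core of compound 3. Also open, from the compounds shown here alone, is how the step would behave on cores that carry only part of the difference between these two.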